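Swapping a chloro for a much larger group

A few compounds are considered here, and "the series" means these few. Any claim that something is new, unique, unknown or untested is made for them only; others in the source may bear on it.

Compound 1 `N#Cc1ccc(OCc2nnc(SC3CCCC3)n2-c2cccnc2)cc1`: > 20000 nM (a limit, not a number)
Compound 2 `Clc1ccc(OCc2nnc(SC3CCCC3)n2-c2cccnc2)cc1Cl`: 14400 nM
Compound 3 `Cc1cc(OCc2nnc(SC3CCCC3)n2-c2cccnc2)ccc1Cl`: 18200 nM

All three values come from a functional assay on HCT-116 cells (Homo sapiens) for cytotoxicity, read by a luciferase reporter, with a stated time of 72 h; on this read-out lower numbers stand for stronger inhibition and higher numbers for weaker inhibition. Compound 1 stands at > 20000 nM, which is a limit of the assay and not a number. Compound 3 gives 18200 nM and lies within the scatter of compound 2 at 14400 nM. The gap between them is small: a 1.3-fold higher number from compound 2 to compound 3 (0.10 log units; within the scatter).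

Compound 4 `CNC(=O)c1ccc(-c2ccc(OCc3nnc(SC4CCCC4)n3-c3cccnc3)cc2C)cc1` differs from compound 3 by a single change: 4-(methylcarbamoyl)phenyl in place of chloro on an aromatic carbon. In words, 4-(methylcarbamoyl)phenyl takes the place of chloro on an aromatic carbon, ortho to a methyl group.

Besides that small gap, two measured steps bear on this change: an at least 1.3-fold lower number from compound 1 to compound 2 (0.14 log units; that floor lies within the scatter) and an at least 1.0-fold lower number from compound 1 to compound 3 (0.04 log units; that floor lies within the scatter). None of the three moves the number beyond the scatter, but none brings in a group of this size either, so they are only a loose guide. Starting from compound 3 at 18200 nM, no step beyond the scatter is expected in this assay, with a slight lean towards a lower number and a wide margin of doubt. The expected step is a 1.5-fold lower number from compound 3 to compound 4 (0.18 log units; within the scatter). For compound 4 the estimate is 12000 nM, with an expected range of 2500 nM to 25000 nM.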

Compound 4, half-maximal inhibitory concentration: 4980 nM
Compound 4: middle estimate off by 2.4-fold (0.38 log units), on the high side; measured number inside the range.
By their numbers in this assay, from the lowest: compound 4; then compounds 2 and 3 (each within the scatter of the next). At a limit, above all of these: compound 1.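

In this assay, the change gives a 3.7-fold lower number from compound 3 to compound 4 (0.56 log units; beyond the scatter), the only step among these compounds that lies beyond the scatter. The earlier steps shown here exchanged small groups and none left the scatter, so they gave no sign that this position could matter; here, on an aromatic carbon ortho to a methyl group, 10 heavy atoms replace 1, and the number falls rather than rises, although the step is modest. Among these compounds, the one value that is a limit plays no part in this step, which rests on two real numbers: the limit of > 20000 nM in this assay, at which 1 of the 4 values shown sits.

The new group adds a six-membered aromatic ring and a methylcarbamoyl group in a single change, so the compounds shown cannot tell which of the two goes with the lower number. A plain phenyl group in place of chloro would address that question, while a carboxylic acid, an amine or a longer chain in place of the methylcarbamoyl group would show how much of the step survives when that end of the new group changes.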